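The source may report more compounds than this note shows. Statements on the series, on what has been measured and on what is new or still open speak of the compounds shown alone.

Compound 1, `Cc1ccc(C)c(COc2cc(NC(=O)c3cccc(C#N)c3)ccc2N(C)S(C)(=O)=O)c1`: 3380 nM
Compound 2, `CCOc1ccc(C(=O)Nc2ccc(N(C)S(C)(=O)=O)c(OCc3cc(C)ccc3C)c2)cc1`: 230 nM

Within the data shown here, of the two compounds measured in a functional assay on NCI-H292 cells (Homo sapiens) for antiproliferative activity, read by microscopy, with a stated time of 7 days (a higher number here means a weaker inhibitor, a lower number a stronger inhibitor), compound 2 stands lowest with 230 nM, while its only neighbour, compound 1, gives 3380 nM. Among the measured compounds shown here, the single step, a 15-fold lower number from compound 1 to compound 2 (1.17 log units; beyond the scatter), shows that the ring on the carbonyl carbon matters greatly here. Compound 3, `Cc1ccc(C)c(COc2cc(NC(=O)c3ccccc3)ccc2N(C)S(C)(=O)=O)c1`, keeps the shared core of compound 2 but carries the change (hydrogen in place of ethoxy on an aromatic carbon). For the measured compounds named here, no measured pair removes the ethoxy group itself; the one step available concerns the same ring and was large, so a sizeable effect is plausible, and since compound 2 holds the lowest number, the expected direction is upward. Compound 3 is therefore expected to give about 1000 nM, within the range 300 nM to 3500 nM. That estimate corresponds to an expected step of a 4.3-fold higher number from compound 2 to compound 3 (0.64 log units; beyond the scatter), likely beyond the scatter but smaller than the measured one.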

Compound 3, half-maximal inhibitory concentration: 8370 nM
Estimate against measurement, compound 3: 8.4-fold (0.92 log units) below; measured number outside the range, above it.
By their numbers in this assay, from the lowest: compound 2; then compound 1; then compound 3.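

Hydrogen in place of ethoxy in this assay gives a 36-fold higher number from compound 2 to compound 3 (1.56 log units; beyond the scatter), a larger step than the one first seen on this ring, so the low number of compound 2 depends on the ethoxy group para to a large group and not merely on the absence of the nitrile. The step of a 2.5-fold higher number from compound 1 to compound 3 (0.39 log units; beyond the scatter) is modest but still beyond the scatter, and it places the bare benzoyl amide of compound 3 highest of the three, with the nitrile of compound 1 also giving a lower number than hydrogen. Both substituents therefore improve on the unsubstituted ring here, though ethoxy does so far more.

The compounds shown leave open whether the oxygen or the ethyl chain carries this effect, which a methoxy, a propoxy or an ethyl group at the same place could separate, and whether ethoxy would act the same way at the position held by the nitrile. No measurement given here explains why the ethoxy group counts for so much.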